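Replacing an oxazole amide with a methylphenyl amide

The source may report more compounds than this note shows. Statements on the series, on what has been measured and on what is new or still open speak of the compounds shown alone.

Measured compounds:
Compound 1, `Cc1ccccc1C(=O)Nc1ncc(-c2ccccc2)n1C`: > 100000 nM
Compound 2, `COc1ccc(-c2cnc(NC(=O)c3ccno3)n2C)cc1`: > 100000 nM

The two measured compounds share an amide-linked core and differ in what sits on the carbonyl carbon and on the aryl arm. In a toxicity assay on THP-1 cells (Homo sapiens) for inhibition (a higher number here means that more compound is tolerated, a lower number that less compound is tolerated), compound 1 gives > 100000 nM, which is a limit of the assay rather than a number. Compound 2 also gives only a limit in this assay, namely > 100000 nM. Among the measured compounds shown here, compound 2 therefore stands at the limit of > 100000 nM in this assay, at which 2 of the 2 values shown sit, and no step between measured compounds can be drawn.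

Compound 3, `COc1ccc(-c2cnc(NC(=O)c3ccccc3C)n2C)cc1`, has yet to be measured. It differs from compound 2 in one place: 2-methylphenyl in place of 1,2-oxazol-5-yl on a carbonyl carbon. The entering 2-methylphenyl group is already present on the carbonyl carbon of compound 1, which is tolerated up to the limit. With both measured compounds at the limit, the step of a number no higher from compound 2 to compound 3 (the limit leaves the size open) is expected to show no change beyond the scatter. For compound 3 the expected value in this assay is 100000 nM, with a range from 40000 nM to 250000 nM, most likely reported once more as a limit.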

Compound 3, half-maximal cytotoxic concentration: > 100000 nM
Compound 3: no number, only a limit (the forecaster's own chance of this, stated with the estimate: 80%); the middle value sits exactly at the limit.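

In this assay compound 3 gives > 100000 nM as a limit of the assay. Among the compounds shown here, no step from compound 1 or compound 2 to compound 3 can be read, since all three compounds stand at the same limit: the limit of > 100000 nM in this assay, at which 3 of the 3 values shown sit. The compounds shown leave open how much of any of the three is actually tolerated, and whether either change has any effect.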